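Swapping a pyridine for a methylimidazole on the sulfonyl

The source may report more compounds than this note shows. Statements on the series, on what has been measured and on what is new or still open speak of the compounds shown alone.

The compounds measured so far:
- compound 1, `CC1CCN(C2CCN(S(=O)(=O)c3cccnc3)CC2)CC1` — 2400 nM
- compound 2, `Cc1cc(C)c(S(=O)(=O)NCCN2CCC(C)CC2)c(C)c1` — 1900 nM
- compound 3, `COc1ccccc1-c1ccc(S(=O)(=O)N2CCC(N3CCC(C)CC3)CC2)cc1` — 26 nM

All three were tested in a functional assay on DLD-1 cells (Homo sapiens) for antiproliferative activity, read by CellTiter-Glo, with a stated time of 72 h; a lower number here means a stronger inhibitor, a higher number a weaker inhibitor. Compound 1 gives the highest number of the three. Its nearest neighbour on the numbers is compound 2, whose value sits within the scatter of repeated measurement, so the two cannot be ordered. Among the compounds with values here, compound 3 lies far away, with a number well beyond the scatter below that of compound 1, and is the only compound of the three with a low value in this assay.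

The unmeasured compound 4, `CC1CCN(C2CCN(S(=O)(=O)c3nccn3C)CC2)CC1`, shares the core of compound 1 and differs from it in a single place: 1-methyl-1H-imidazol-2-yl in place of pyridin-3-yl on a sulfonyl sulfur. The new ring is of the same size in heavy atoms as the one it replaces. Within the data shown here, no measured pair here tells how such a change at the sulfonyl sulfur plays out, so the direction is open. The expectation is that this change does no more than move compound 4 within the scatter around compound 1, with a step of a 1.3-fold higher number from compound 1 to compound 4 (0.10 log units; within the scatter) that is estimated to be small. Compound 4 is therefore expected to give about 3000 nM, in a range from 900 nM to 10000 nM.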

Compound 4, half-maximal inhibitory concentration: > 5000 nM
Compound 4 ended at the assay's limit; the forecaster's own chance of this, stated with the estimate: 15%; middle value at least 1.6-fold (0.22 log units) away from the limit.
By their numbers in this assay, from the lowest: compound 3; then compounds 2 and 1 (each within the scatter of the next). At a limit, above all of these: compound 4.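

In this assay compound 4 gives > 5000 nM as a limit of the assay and not a number. Within the data shown here, this is the first step at the sulfonyl sulfur with the rest of the structure held fixed: placing 1-methyl-1H-imidazol-2-yl in place of pyridin-3-yl gives an at least 2.0-fold higher number from compound 1 to compound 4 (0.31 log units; beyond the scatter) and so goes beyond the scatter. The position therefore does not treat these two aromatic rings alike, even though they have the same heavy-atom count, and the result fixes only the smallest possible size of the step, not its full size, as this shows: the limit of > 5000 nM in this assay, at which 1 of the 4 values shown sits.

The compounds shown cannot separate the effect of the five-membered ring from that of the methyl on it, so an imidazole without the methyl or a pyrazole would be needed to tell the two apart. They also leave open whether a small substituent on the pyridin-3-yl ring, such as an amine or a methoxy group, would move the number in either direction from that of compound 1 while the rest of the structure stays the same.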